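From amino to dimethylamino on the carbonyl carbon

This account rests on a few compounds, and the source may have more. Where it says the series, first, only, none or still open, it means among the compounds named here.

Compound 1 `CN1CCN(C(=O)/C=C/c2ccncc2-c2ccc3ccccc3c2)CC1`: > 10000 nM
Compound 2 `NC(=O)/C=C/c1ccncc1-c1ccc2ccccc2c1`: > 10000 nM

In a functional assay on KB cells (Homo sapiens) for inhibition, read by sulforhodamine B assay, with a stated time of 72 h (on this read-out lower numbers stand for stronger inhibition of growth and higher numbers for weaker inhibition of growth), compound 2 gives > 10000 nM, which is a limit of the assay and not a number. Compound 1 also stands at a limit, > 10000 nM. The record so far is therefore (the limit of > 10000 nM in this assay, at which 2 of the 2 values shown sit), and neither compound has yet given a readable growth-inhibition value.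

Compound 3 `CN(C)C(=O)/C=C/c1ccncc1-c1ccc2ccccc2c1` keeps the core of compound 2 and differs in one place: dimethylamino in place of amino on a carbonyl carbon. Dimethylamino takes the place of amino on a carbonyl carbon, and the hydrogen-bond donor counted on amino is gone.

Going by the values given here, one measured step bears on this change, at the same carbonyl carbon: a step that the two limits leave unreadable from compound 1 to compound 2. Its size cannot be read, so it offers no firm guide to size or direction. Going by that step, no change beyond the usual scatter is expected in this assay, and the estimated step is a step that the limit leaves unreadable from compound 2 to compound 3. Compound 3 is expected near 12000 nM, with an estimated range from 5000 nM to 30000 nM, and the assay will probably report only a limit.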

Compound 3, concentration for 50% growth inhibition: 7760 nM
Estimate against measurement, compound 3: 1.5-fold (0.19 log units) above; the measured number falls inside the stated range.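

In this assay compound 3 gives 7760 nM, the first result at this carbonyl carbon that is a number and not a limit of the assay. Dimethylamino in place of amino amounts to an at least 1.2-fold lower number from compound 2 to compound 3 (0.11 log units; that floor lies within the scatter), and dimethylamino in place of 4-methylpiperazin-1-yl amounts to an at least 1.2-fold lower number from compound 1 to compound 3 (0.11 log units; that floor lies within the scatter), so each comparison yields only a floor, and neither floor establishes a real gain in growth inhibition. The step between the two other compounds still cannot be read, and most of the record remains at the limit: the limit of > 10000 nM in this assay, at which 2 of the 3 values shown sit.

The compounds shown leave open whether the readable number goes with the loss of the amide hydrogen or with the two added carbons, a question that methylamino on the same carbonyl carbon would help to separate. They also leave open how the number would respond to longer chains, as in diethylamino, or to a ring without the second amine of the methylpiperazine, as in pyrrolidin-1-yl.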